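The source may hold more compounds than are shown below. What is called first, only, known or untested is meant among the compounds shown, and "the series" means these compounds.

Among the measured compounds shown here, in a physicochemical assay for solubility (on this read-out higher numbers stand for higher solubility and lower numbers for lower solubility), compound 3 `CC(C)COc1cc(C(F)(F)F)nn1-c1ccc(S(C)(=O)=O)cn1` gives 50 ug/mL, the sole reading so far. Compound 1 `CC1CCCN(c2cc(C(F)(F)F)nn2-c2ccc(S(C)(=O)=O)cn2)C1` reads "not determined" (no result reported) and compound 2 `CS(=O)(=O)c1ccc(-n2nc(C(F)(F)F)cc2NC2CCC2)nc1` reads "not determined" (no result reported), so compound 3 cannot yet be ranked against anything. Compound 4 `CS(=O)(=O)c1ccc(-n2nc(C(F)(F)F)cc2OC2CCCC2)nc1` keeps the shared core and carries cyclopentyl in place of isobutyl on an oxygen on an aromatic ring, a change that counts out as cyclopentyl in place of isobutyl on an oxygen on an aromatic ring in full. For the measured compounds named here, no measured pair shows what such a swap does, so the expectation is no change beyond the usual scatter, if anything a small drop. The estimated size is a 1.3-fold lower number from compound 3 to compound 4 (0.10 log units; within the scatter) for this swap. Compound 4 is expected at 40 ug/mL with an estimated range from 15 ug/mL to 90 ug/mL in this test.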

Compound 4, solubility: 50 ug/mL
Beside the measured number, compound 4's estimate is 1.3-fold (0.10 log units) below it, within the range that was stated.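

In this assay, among the compounds shown here, the oxygen on the aromatic ring carries cyclopentyl in place of isobutyl with no change at the digits printed from compound 3 to compound 4 (within the scatter), the first step that can be read at this place. Here, a group with a five-membered ring of carbon only and a group with no ring give the same reading. No measurement at hand accounts for this result. The steps to compound 1 and compound 2 cannot be read, with no number for either. On these data alone, whether a longer chain or a carboxylic acid on this oxygen would shift the reading remains open.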